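The source may report more compounds than this note shows. Statements on the series, on what has been measured and on what is new or still open speak of the compounds shown alone.

Measured so far in a functional assay on the whole organism (blood) with Rattus norvegicus as the target, with stated times of 24 h and 1 h, at a dose of 5 mg/kg by the intraperitoneal route; on this read-out lower numbers stand for a weaker effect and higher numbers for a stronger effect at the one dose given:

compound 1 `CC(=O)NCCC1CCN(S(=O)(=O)NC(=O)NC[C@@H]2C[C@@H]3C=C[C@@H]2C3)CC1` — 18%
compound 2 `O=C(NC1CCCCC1)NS(=O)(=O)N1CCC(CCNC(=O)c2ccnc3ccccc23)CC1` — 16%

Among the measured compounds shown here, two compounds have been run in this assay, and their numbers sit within the usual scatter of each other: compound 1 gives 18% and compound 2 gives 16%, so neither can be set above the other, and no step between them can be read as a real one. Compound 1 is the reference for the next compound.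

Compound 3 `O=C(NC[C@@H]1C[C@@H]2C=C[C@@H]1C2)NS(=O)(=O)N1CCC(CCNC(=O)c2cccc3cccnc23)CC1` has not yet been measured in this assay. It differs from compound 1 as follows: quinolin-8-yl in place of methyl on a carbonyl carbon. For the measured compounds named here, no pair of measured compounds shows this difference alone, so no step of known size is available; compound 2 carries a quinolinyl carbonyl of its own and still gives a number within the scatter of compound 1. On that basis a step in this assay no larger than the scatter is expected, in no fixed direction, as no change at the digits printed from compound 1 to compound 3 (within the scatter). Compound 3 is therefore estimated at 18%, with a range from 7% to 32%.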

Compound 3, a percentage reported as activity, at one dose (the size of the read-out at that dose, not a potency): 34%
Compound 3: middle estimate off by 16 percentage points, on the low side; the measured number lies above the stated range.
By their numbers in this assay, from the lowest: compounds 2 and 1 (each within the scatter of the next); then compound 3.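

In this assay, among the compounds shown here, quinolin-8-yl in place of methyl on a carbonyl carbon gives a number 16 percentage points higher from compound 1 to compound 3 (beyond the scatter) and so provides the first step that can be read as real. This position therefore accepts a much larger group than methyl without loss at the one dose given, and the read-out rises with this change. Nothing available accounts for this step.

For the compounds shown here, the single pair cannot separate the contribution of the ring nitrogen from that of the two aromatic rings, so a naphthalen-1-yl or a phenyl group on the same carbonyl carbon would be the informative comparison. Going by these compounds, whether the step holds at other doses also remains open, since the read-out gives the size of the effect at one dose and not a potency.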